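The compounds below may be only part of what the source reports. "The series", "measured", "known", "first", "only" and "open" are said of these compounds alone.

Compound 1 `Cc1ccc(C(=O)Nc2cccc(C(F)(F)F)c2)cc1-c1ccc2c(-c3ccc(CN4CCN(C)CC4)cc3)n[nH]c2c1`: 6.2 nM
Compound 2 `Cc1ccc(C(=O)Nc2cccc(C(F)(F)F)c2)cc1-c1ccc2c(-c3cnn(C)c3)n[nH]c2c1`: 4.4 nM

In an assay on isolated protein for inhibition of Discoidin domain-containing receptor 2 (Homo sapiens), read by ELISA, with a stated time of 60 min (a lower number here means a stronger inhibitor, a higher number a weaker inhibitor), compound 1 gives 6.2 nM and compound 2 gives 4.4 nM; the two numbers lie within the usual scatter of each other, so neither compound is set apart on this evidence. Compound 3 `Cc1ccc(C(=O)Nc2cccc(C(F)(F)F)c2)cc1-c1ccc2c(-c3cnn(CC(=O)N(C)C)c3)n[nH]c2c1` differs from compound 2 by dimethylcarbamoyl in place of hydrogen on a saturated chain carbon bound to an aromatic nitrogen. Going by the values given here, no measured pair shows a step of this kind, so the data offer no guide to its size. With the new group entering on a saturated chain carbon bound to an aromatic nitrogen, compound 3 is expected to move little beyond the scatter, a 1.3-fold higher number from compound 2 to compound 3 (0.10 log units; within the scatter). Compound 3 is therefore estimated at 5.5 nM, in a range from 2 nM to 15 nM.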

Compound 3, half-maximal inhibitory concentration: 2.7 nM
Compound 3: middle estimate off by 2.0-fold (0.31 log units), on the high side; measured number inside the range.
By their numbers in this assay, from the lowest: compounds 3, 2 and 1 (each within the scatter of the next, the first and the last beyond it).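

In this assay, dimethylcarbamoyl in place of hydrogen on a saturated chain carbon bound to an aromatic nitrogen gives a 1.6-fold lower number from compound 2 to compound 3 (0.21 log units; within the scatter). Going by these compounds alone, this is the first single-place step, and it shows that this carbon can carry the larger dimethylcarbamoyl group with no change beyond the scatter. Nothing available accounts for this result. The compounds shown leave open whether an amine, a carboxylic acid or a longer chain on the same carbon would also stay within the scatter of compound 2.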